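A few compounds are considered here, and "the series" means these few. Any claim that something is new, unique, unknown or untested is made for them only; others in the source may bear on it.

Measured so far in a physicochemical assay for acid dissociation, read by spectrophotometry, at pH 2:
- compound 1 `COc1ccc(Nc2nc(Cl)cn([C@H](C)C3CC3)c2=O)c(C)n1` gives 3.2
- compound 2 `COc1cc(C)c(Nc2nc(Cl)cn([C@H](C)C3CC3)c2=O)c(C)n1` gives 3.8

Of these two numbers, the higher belongs to compound 2 at 3.8 and the lower to compound 1 at 3.2, a gap beyond the scatter.

Next comes compound 3 `Cc1cc(C)c(Nc2nc(Cl)cn([C@H](C)C3CC3)c2=O)c(C)n1`, not yet measured. It differs from compound 2 in one place: methyl in place of methoxy on an aromatic carbon. This is methyl in place of methoxy on an aromatic carbon, next to the ring nitrogen and para to a large group.

Among the measured compounds shown here, only one measured step is available: a number 0.60 log units higher from compound 1 to compound 2 (beyond the scatter). That modest step is methyl in place of hydrogen on an aromatic carbon, a different change at a different place, so it bears only loosely. For the measured compounds named here, no measured pair here replaces methoxy with methyl, and the size expected below is a judgement rather than a read-across. Starting from compound 2 at 3.8, a move to a higher number is expected, larger than the one measured step. In this assay the expected step is a number 1.70 log units higher from compound 2 to compound 3 (beyond the scatter) by this estimate. Compound 3 is estimated at 5.5, with an expected range from 4.7 to 6.3 as the working figures.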

Compound 3, acid dissociation constant: 7.9
For compound 3 the middle estimate is 2.40 log units below the measured one, outside the stated range (above it).
By their numbers in this assay, from the lowest: compound 1; then compound 2; then compound 3.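

In this assay, the methoxy-to-methyl change on the aromatic carbon next to the ring nitrogen gives a number 4.10 log units higher from compound 2 to compound 3 (beyond the scatter), so this position has a large effect on the read-out. Among the compounds shown here, the only earlier step, a number 0.60 log units higher from compound 1 to compound 2 (beyond the scatter), is a modest one from a different change at a different place, and it gave no sign that a single replacement on this ring could move the number so far. No measurement available here bears on the origin of this large step.

From the compounds shown here alone, with only methoxy and methyl seen on this carbon, it remains open whether the step tracks the departure of methoxy or the arrival of methyl, and an ethyl group or a dimethylamino group at the same carbon could tell the two apart. Going by these compounds, it is also open whether the same replacement gives a step of similar size without the methyl group that separates compound 1 from compound 2, as the step has been read only with both methyl groups in place.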